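The source may hold more compounds than are shown below. What is called first, only, known or untested is meant among the compounds shown, and "the series" means these compounds.

Measured so far:
compound 1, `C/N=C(/S)C1=CC(C)(CF)Oc2ccc([N+](=O)[O-])cc21`, 77.1%
compound 2, `C/N=C(/S)C1=CC(CF)(CF)Oc2ccc([N+](=O)[O-])cc21`, 74.5%
compound 3, `CNC(=O)C1=CC(C)(C(F)(F)F)Oc2ccc([N+](=O)[O-])cc21`, 61.7%

These three values come from a functional assay on the whole organism (aorta) with Rattus norvegicus as the target; a higher number here means a larger maximal response, a lower number a smaller maximal response. Compound 2 has the second highest of the three numbers. Its nearest neighbour is compound 1, and the step of a number 2.6 percentage points lower from compound 1 to compound 2 (within the scatter) is within the scatter, so the two cannot be told apart. Compound 3 differs from compound 2 in more than one place; its value lies lower, beyond the scatter.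

Compound 4, `N#CCC/N=C(\S)C1=CC(CF)(CF)Oc2ccc([N+](=O)[O-])cc21`, has not yet been measured. It differs from compound 2 in one place: a group of 7 heavy atoms (4 carbon, 2 nitrogen, 1 sulfur; no ring) in place of a group of 4 heavy atoms (2 carbon, 1 nitrogen, 1 sulfur; no ring), on a double-bonded ring carbon

For the measured compounds named here, the only measured step that changes a single place, the one from compound 1 to compound 2, concerns the fluoromethyl groups on the saturated ring carbon, not the group on the double-bonded ring carbon, so it does not bear directly on this change. Going by the values given here, no measured pair shows what replacing the group on the double-bonded ring carbon does. With nothing to point in either direction, the expected step in this assay is none beyond the scatter, though the uncertainty is wide. For compound 4 the estimate is 70%, with a range from 52% to 85%. This estimate corresponds to an expected step of a number 4.5 percentage points lower from compound 2 to compound 4 (within the scatter).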

Compound 4, intrinsic activity: the largest response reached, in percent of the reference agonist's: 72.5%
Estimate against measurement, compound 4: 2.5 percentage points below; low and high end bracket the measured number.
By their numbers in this assay, from the lowest: compound 3; then compounds 4, 2 and 1 (each within the scatter of the next).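

In this assay, putting the group of 7 heavy atoms (4 carbon, 2 nitrogen, 1 sulfur) in place of the group of 4 heavy atoms on the double-bonded ring carbon gives a number 2 percentage points lower from compound 2 to compound 4 (within the scatter), so the two compounds cannot be told apart. For the compounds shown here, this is the first single-place comparison at this position, and it shows that the maximal response in this pair holds within the scatter when the group grows and gains a nitrile, with its triple bond and added hydrogen-bond acceptor. No measurement at hand offers an explanation for this result.

With two fluoromethyl groups on the ring atom, the compounds shown compare only these two groups on the double-bonded ring carbon, so it remains open whether a longer chain, or a chain ending in an amine or a carboxylic acid instead of a nitrile, would also leave the maximal response within the scatter. From the compounds shown here alone, it also remains open whether the same replacement would give a similar result in the core of compound 1, which has one methyl and one fluoromethyl group on that ring atom.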